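This account rests on a few compounds, and the source may have more. Where it says the series, first, only, none or still open, it means among the compounds named here.

Measured in a functional assay on a cell-free system (plasma, Homo sapiens) for inhibition, with Plasma (Rattus norvegicus) as the target; a higher number here means a weaker inhibitor, a lower number a stronger inhibitor:
- compound 1 `O=c1cc(N2CCNCC2)c2ccc(OCc3ccccc3)cc2o1`: 78800 nM
- compound 2 `Cc1c(OCc2cccnc2)ccc2c(N3CCNCC3)cc(=O)oc12`: 1420 nM
- compound 3 `CCCCOc1ccc2c(N3CCNCC3)cc(=O)oc2c1C`: 5030 nM

Compound 3, at 5030 nM, has the second highest of the three numbers. Compound 2 has a lower number at 1420 nM, and compound 1 a higher one at 78800 nM.

Next in the series is compound 4 `CSCOc1ccc2c(N3CCNCC3)cc(=O)oc2c1C`, not yet measured. It differs from compound 3 as follows: methylsulfanyl in place of propyl on a saturated chain carbon bound to an oxygen on an aromatic ring. In words, methylsulfanyl stands in place of propyl on a saturated chain carbon bound to an oxygen on an aromatic ring, which also reads as butoxy to (methylsulfanyl)methoxy.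

Within the data shown here, only one measured step falls at this place: a 3.5-fold higher number from compound 2 to compound 3 (0.55 log units; beyond the scatter). That step, which brought propyl in place of pyridin-3-yl, was modest and removed a ring. Among the measured compounds shown here, no ring enters or leaves on the way to compound 4, and no single-place step links compound 1 to the others. For the measured compounds named here, the data therefore support no direction, and in this assay a step smaller than the one to compound 3 is expected, most likely none beyond the scatter. The estimated step is a 1.3-fold lower number from compound 3 to compound 4 (0.10 log units; within the scatter). The expected value for compound 4 is 4000 nM, with an estimated range of 1600 nM to 10000 nM.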

Compound 4, half-maximal inhibitory concentration: 3400 nM
The estimate for compound 4 lay 1.2-fold (0.07 log units) above the measured number; low and high end bracket the measured number.
By their numbers in this assay, from the lowest: compound 2; then compounds 4 and 3 (each within the scatter of the next); then compound 1.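

In this assay, methylsulfanyl in place of propyl on a saturated chain carbon bound to an oxygen on an aromatic ring gives a 1.5-fold lower number from compound 3 to compound 4 (0.17 log units; within the scatter) and so leaves butoxy and (methylsulfanyl)methoxy indistinguishable here, although methylsulfanyl brings sulfur and a hydrogen-bond acceptor that propyl lacks. Pyridin-3-yl at this place now has a second comparison, a 2.4-fold higher number from compound 2 to compound 4 (0.38 log units; beyond the scatter) and, like the earlier 3.5-fold higher number from compound 2 to compound 3 (0.55 log units; beyond the scatter), it shows a higher number once that ring is replaced by an open-chain group, so both open-chain groups shown go the same way against pyridin-3-yl. Nothing measured here accounts for these steps.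

The compounds shown leave open whether the lower number with pyridin-3-yl belongs to that ring alone or would also appear with another ring on the same carbon, such as pyridin-4-yl or thiophen-2-yl. They also leave open what a longer chain such as hexyl, or a chain ending in a carboxylic acid, would do at this place, and compound 1 gives no reading on either question, as it differs from the others in more than one place.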